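This account rests on a few compounds, and the source may have more. Where it says the series, first, only, none or still open, it means among the compounds named here.

Measured so far in a functional assay on HT cells (Homo sapiens) for antiproliferative activity, read by fluorescence, with a stated time of 72 h; a higher number here means a weaker inhibitor of growth, a lower number a stronger inhibitor of growth:
- compound 1 `CC(O)CSc1nc(NCc2ccc(-c3ccccn3)cc2)c2[nH]nc(C(C)C)c2n1`, which gives 62 nM;
- compound 2 `CC(C)c1n[nH]c2c(NCc3ccc(-c4ccccn4)cc3)nc(SCCCN(C)C)nc12`, which gives 105 nM;
- compound 3 `CC(C)c1n[nH]c2c(NCc3ccc(-c4ccccn4)cc3)nc(SCCn3ccnc3)nc12`, which gives 155 nM.

Compound 3 stands at the highest of these three numbers. Against compound 2 the step of a 1.5-fold higher number from compound 2 to compound 3 (0.17 log units; within the scatter) lies within the scatter, so the two cannot be ranked. Against compound 1 the step of a 2.5-fold higher number from compound 1 to compound 3 (0.40 log units; beyond the scatter) is modest but beyond the scatter.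

Compound 4 `CCC(CO)Sc1nc(NCc2ccc(-c3ccccn3)cc2)c2[nH]nc(C(C)C)c2n1` differs from compound 3 in one place: 1-(hydroxymethyl)propyl in place of 2-(1H-imidazol-1-yl)ethyl on a sulfur. Going by the values given here, the entering group, like the group on the sulfur of compound 1, is a short chain bearing a hydroxyl, while the leaving group is the one that set compound 3 apart from compound 1. The step that bears on the change is a 2.5-fold higher number from compound 1 to compound 3 (0.40 log units; beyond the scatter), read in reverse; the step of a 1.7-fold higher number from compound 1 to compound 2 (0.23 log units; within the scatter) adds that the chains tried so far differ little among themselves. For compound 4 a modest move toward a lower number is therefore expected, a 2.2-fold lower number from compound 3 to compound 4 (0.35 log units; beyond the scatter). The estimate for compound 4 is 70 nM, with a range from 30 nM to 160 nM.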

Compound 4, concentration for 50% growth inhibition: 255 nM
Estimate against measurement, compound 4: 3.6-fold (0.56 log units) below; measured number above the stated range.
By their numbers in this assay, from the lowest: compounds 1, 2, 3 and 4 (each within the scatter of the next, the first and the last beyond it).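

A hydroxyl on the group on the sulfur does not by itself keep the number low: compound 1 and compound 4 both carry one, yet changing 2-hydroxypropyl to 1-(hydroxymethyl)propyl gives the largest step in this set (a 4.1-fold higher number from compound 1 to compound 4 (0.61 log units; beyond the scatter)). The same entering group is modestly separated from 3-(dimethylamino)propyl (a 2.4-fold higher number from compound 2 to compound 4 (0.39 log units; beyond the scatter)), but it cannot be ranked against 2-(1H-imidazol-1-yl)ethyl (a 1.6-fold higher number from compound 3 to compound 4 (0.22 log units; within the scatter)). Nothing given here accounts for the gap between the two hydroxyl-bearing groups.

Going by these compounds, it remains open which feature of 1-(hydroxymethyl)propyl carries the step from 2-hydroxypropyl, as the two groups differ in both carbon chain and hydroxyl placement. A plain propyl group on the sulfur, or a short chain ending in a carboxylic acid, would test whether the hydroxyl matters at all.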